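Piperidinyl in Place of Dipentylamino on a Fused Core

The source may hold more compounds than are shown below. What is called first, only, known or untested is meant among the compounds shown, and "the series" means these compounds.

Of the compounds shown here, two have been measured in a functional assay on HepG2 cells (Homo sapiens) for cytotoxicity, read by MTT assay, with a stated time of 72 h; a lower number here means a stronger inhibitor, a higher number a weaker inhibitor. Compound 1 `CCCCN(CCCC)c1nc2c(ncn2-c2ccccc2)c(=O)n1-c1ccccc1` gives 20400 nM. Compound 2 `CCCCCN(CCCCC)c1nc2c(ncn2-c2ccccc2)c(=O)n1-c1ccc(Cl)cc1` is recorded only as a limit, > 100000 nM, so no number for it is known. In this assay compound 2 therefore sits at the limit of > 100000 nM in this assay, at which 1 of the 2 values shown sits. Compound 3 `O=c1c2ncn(-c3ccccc3)c2nc(N2CCCCC2)n1-c1ccc(Cl)cc1` differs from compound 2 by piperidin-1-yl in place of dipentylamino on an aromatic carbon. Going by the values given here, no measured step between two compounds is available, so the size of this change in this assay can only be guessed. The step from compound 2 to compound 3 is expected to be an at least 1.6-fold lower number from compound 2 to compound 3 (0.22 log units; that floor lies within the scatter), staying on the weak side. Compound 3 is estimated at 60000 nM, between 15000 nM and 200000 nM.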

Compound 3, half-maximal inhibitory concentration: > 100000 nM
Compound 3 ended at the assay's limit (the forecaster's own chance of this, stated with the estimate: 40%); at least 1.6-fold (0.22 log units) between middle value and limit.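

No step can be read from compound 2 to compound 3, since each is recorded only as a limit: the limit of > 100000 nM in this assay, at which 2 of the 3 values shown sit. The compounds shown leave open whether piperidin-1-yl in place of dipentylamino changes the cytotoxicity reading at all.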